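This account rests on a few compounds, and the source may have more. Where it says the series, first, only, none or still open, it means among the compounds named here.

Measured so far:
Compound 1 `O=C(Nc1cccc(-n2cc(-c3ccncc3)c(-c3ccc(Cl)c(O)c3)n2)c1)Nc1cccc(C(F)(F)F)c1` in a functional assay on HCT-116 cells (Homo sapiens) for inhibition, read by sulforhodamine B assay, with a stated time of 48 h (a lower number here means a stronger inhibitor of growth, a higher number a weaker inhibitor of growth), compound 1 gives 1390 nM.
Compound 2 `COc1cc(-c2nn(-c3cccc(NC(=O)Nc4cc(C(F)(F)F)cc(C(F)(F)F)c4)c3)cc2-c2ccncc2)ccc1Cl` in this assay compound 2 gives 643 nM.

Compound 2 holds the lower of the two numbers, and compound 1 sits more than the usual scatter above it. Compound 3 `O=C(Nc1cccc(-n2cc(-c3ccncc3)c(-c3ccc(Cl)c(O)c3)n2)c1)Nc1cc(C(F)(F)F)cc(C(F)(F)F)c1` is the unmeasured partner of compound 2; the change is hydrogen in place of methyl on an oxygen on an aromatic ring. Among the compounds with values here, no measured pair shows this change alone, so its size is not known from the data. The step from compound 2 to compound 3 is expected to be small, possibly within the scatter, a 1.3-fold higher number from compound 2 to compound 3 (0.12 log units; within the scatter). Compound 3 is therefore estimated at 850 nM, with a range from 300 nM to 2400 nM.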

Compound 3, concentration for 50% growth inhibition: 428 nM
Beside the measured number, compound 3's estimate is 2.0-fold (0.30 log units) above it, and the stated range covers the measured number.
By their numbers in this assay, from the lowest: compounds 3 and 2 (each within the scatter of the next); then compound 1.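

In this assay, hydroxy in place of methoxy gives a 1.5-fold lower number from compound 2 to compound 3 (0.18 log units; within the scatter), so this first matched pair shows the two groups on this oxygen cannot be told apart here. The second trifluoromethyl on an aromatic carbon, read on the hydroxy compounds, gives a 3.2-fold lower number from compound 1 to compound 3 (0.51 log units; beyond the scatter), a modest step that stands clear of the scatter. Nothing measured here gives a cause for either step. As far as these compounds go, each change rests on a single pair, so its size in other settings stays open. From the compounds shown here alone, whether an ethoxy group or an amine would serve at the oxygen position, or a nitrile in place of the second trifluoromethyl, also remains open.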